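Predicting clearance of a pyridin-3-yl amide analogue

The source may hold more compounds than are shown below. What is called first, only, known or untested is meant among the compounds shown, and "the series" means these compounds.

This account starts from compound 1, `CN1C[C@H](C(=O)Nc2ccc(C(F)(F)F)cc2)[C@@H](c2ccc(/C=C/C(=O)Nc3ccccc3N)cc2)C1`, which in an in vitro ADME assay on microsomes from liver (Homo sapiens) for pharmacokinetics, read by LC-MS, with a stated time of 10 min, tested at 1 uM (on this read-out higher numbers stand for fast clearance and lower numbers for slow clearance), gives 6 mL/min/kg. Among the three measured compounds, compound 1 has the lowest number; its nearest neighbour is compound 3, `CN1C[C@H](C(=O)Nc2ccc(F)cc2F)[C@@H](c2ccc(/C=C/C(=O)Nc3ccccc3N)cc2)C1`, which in this assay gives 12 mL/min/kg, and the furthest is compound 2, `CN1C[C@H](C(=O)Nc2ccc(F)c(Cl)c2)[C@@H](c2ccc(/C=C/C(=O)Nc3ccccc3N)cc2)C1`, which in this assay gives 15 mL/min/kg. The two measured steps from compound 1 both change the aryl group on the amide-type nitrogen: a 2.5-fold higher number from compound 1 to compound 2 (0.40 log units; beyond the scatter) and a 2.0-fold higher number from compound 1 to compound 3 (0.30 log units; within the scatter). Between the two halogenated analogues, a 1.3-fold lower number from compound 2 to compound 3 (0.10 log units; within the scatter).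

Compound 4, `CN1C[C@H](C(=O)Nc2cccnc2)[C@@H](c2ccc(/C=C/C(=O)Nc3ccccc3N)cc2)C1`, differs from compound 1 at the same place: pyridin-3-yl in place of 4-(trifluoromethyl)phenyl on an amide-type nitrogen. Among the measured compounds shown here, no measured compound carries a pyridin-3-yl group, so the bearing of the earlier steps is indirect. Both replacements of 4-(trifluoromethyl)phenyl that were measured gave higher numbers, one beyond the scatter and one within it. Compound 4 is therefore expected to show a modest rise, a 1.8-fold higher number from compound 1 to compound 4 (0.26 log units; within the scatter), though a result within the scatter would not surprise. The estimate for compound 4 in this assay is 11 mL/min/kg, with a range from 5 mL/min/kg to 25 mL/min/kg.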

Compound 4, clearance: 10 mL/min/kg
Compound 4: the middle estimate sits 1.1-fold (0.04 log units) above what was measured; low and high end bracket the measured number.
By their numbers in this assay, from the lowest: compounds 1, 4, 3 and 2 (each within the scatter of the next, the first and the last beyond it).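

With pyridin-3-yl on the amide-type nitrogen, in this assay the step is a 1.7-fold higher number from compound 1 to compound 4 (0.22 log units; within the scatter), so this smaller aryl group, which has a ring nitrogen and no halogen, does not separate from 4-(trifluoromethyl)phenyl by more than the usual scatter. It also stays within the scatter of both halogenated analogues, with a 1.2-fold lower number from compound 3 to compound 4 (0.08 log units; within the scatter) and a 1.5-fold lower number from compound 2 to compound 4 (0.18 log units; within the scatter), so at this place a ring with a hetero atom and a hydrogen-bond acceptor reads much the same as the 2,4-difluorophenyl and 3-chloro-4-fluorophenyl rings. Nothing at hand bears on what lies behind these numbers.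

As far as these compounds go, it remains open whether pyridin-2-yl or pyridin-4-yl, or a non-aromatic group such as a morpholine ring or an open alkyl chain, would stay within this same span of clearance values at the amide-type nitrogen. All four compounds share the core of compound 1, so the result does not say how the same exchange would read on a different core or with the aminophenyl amide end altered.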